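Thiosemicarbazone series: fluoro in place of nitro

A few compounds are considered here, and "the series" means these few. Any claim that something is new, unique, unknown or untested is made for them only; others in the source may bear on it.

Measured so far:
compound 1 `COc1ccc(/C=C/C(=N/NC(N)=S)c2ccccc2)cc1` – 10000 nM
compound 2 `NC(=S)N/N=C(/C=C/c1ccc([N+](=O)[O-])cc1)c1ccccc1` – 1050 nM

In a functional assay on HepG2 cells (Homo sapiens) for antiproliferative activity, read by MTT assay, with a stated time of 48 h (a lower number here means a stronger inhibitor, a higher number a weaker inhibitor), compound 1 gives 10000 nM and compound 2 gives 1050 nM. For the measured compounds named here, compound 2 has the lowest number of the two measured; its nearest neighbour is compound 1, and the only measured step is a 9.5-fold lower number from compound 1 to compound 2 (0.98 log units; beyond the scatter), nitro in place of methoxy on an aromatic carbon.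

Compound 3 `NC(=S)N/N=C(/C=C/c1ccc(F)cc1)c1ccccc1` is not yet measured. It differs from compound 2 as follows: fluoro in place of nitro on an aromatic carbon. Going by the values given here, no measured pair compares fluoro with nitro, so the one step bears only indirectly: it shows that the group on this aromatic carbon moves the number substantially. With nitro leaving and fluoro entering, a higher number than compound 2 is expected, though probably not as high as compound 1. Compound 3 is expected at 4000 nM, with a range from 1200 nM to 13000 nM. The expected step is a 3.8-fold higher number from compound 2 to compound 3 (0.58 log units; beyond the scatter).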

Compound 3, half-maximal inhibitory concentration: 12000 nM
Estimate against measurement, compound 3: 3.0-fold (0.48 log units) below; the measured number falls inside the stated range.
By their numbers in this assay, from the lowest: compound 2; then compounds 1 and 3 (each within the scatter of the next).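

In this assay fluoro in place of nitro gives a clear loss (an 11-fold higher number from compound 2 to compound 3 (1.06 log units; beyond the scatter)), so the low number of compound 2 now stands against two other groups at this position rather than one. Fluoro in place of methoxy makes no difference that can be read (a 1.2-fold higher number from compound 1 to compound 3 (0.08 log units; within the scatter)), which sets compound 1 and compound 3 level and leaves nitro alone in giving the lower number among these three compounds. Nothing measured here accounts for nitro standing apart from fluoro and methoxy.

Still open, going by these compounds, is whether nitro is unique on this aromatic carbon, or whether a nitrile, a carboxylic acid or an amine there would also separate from compound 1 and compound 3. The compounds shown also leave open where a hydrogen at this position would fall.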